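The source may report more compounds than this note shows. Statements on the series, on what has been measured and on what is new or still open speak of the compounds shown alone.

Measured compounds:
compound 1 `CC1CCC(=NNc2ccc(Cl)c(Cl)c2)c2ncc(C(=O)O)c(=O)n21` — a limit only, > 100 umol/kg
compound 2 `COc1cc(OC)c(NN=C2CCC(C)n3c2ncc(C(=O)O)c3=O)cc1Cl` — a limit only, > 100 umol/kg
compound 3 `CC1CCC(=NNc2cccc3ccccc23)c2ncc(C(=O)O)c(=O)n21` — a limit only, > 320 umol/kg

All three values come from a functional assay on the whole organism with Rattus norvegicus as the target; on this read-out higher numbers stand for an effect only at larger amounts of compound and lower numbers for an effect already at smaller amounts. Compound 1 gives no number there, only the limit > 100 umol/kg. Compound 2 likewise stops at the limit > 100 umol/kg. For compound 3 the assay reports the limit > 320 umol/kg. So compound 1 stands at the limit of > 100 umol/kg in this assay, at which 2 of the 3 values shown sit, alongside compound 2, while compound 3 sits at the limit of > 320 umol/kg in this assay, at which 1 of the 3 values shown sits; none of the three shows an effect within the doses tested, and no number places compound 1 anywhere inside the range of the assay.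

Compound 4 `CC1CCC(=NNc2ccccn2)c2ncc(C(=O)O)c(=O)n21` differs from compound 1 in one place: pyridin-2-yl in place of 3,4-dichlorophenyl on an amine nitrogen. For the measured compounds named here, no step between measured compounds is available to show how such a change moves the dose in this assay. With compound 1 itself only at a limit, the step is expected to be none beyond the scatter, and compound 4 is expected to remain at or near the same limit. The estimate for compound 4 in this assay is 150 umol/kg, with a range from 50 umol/kg to 500 umol/kg. For compound 4 the expected step is a step that the limit leaves unreadable from compound 1 to compound 4.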

Compound 4, dose for 50% inhibition: > 100 umol/kg
Compound 4: only a limit was reported (the forecaster's own chance of this, stated with the estimate: 75%); the middle value is on the limit's open side.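

Compound 1 and compound 4 each give only a limit, not a number, so no step can be read between them. The compounds shown leave open whether either one has an effect at some larger dose, and how swapping 3,4-dichlorophenyl for pyridin-2-yl would then move it.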